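Fluoro on the benzyl ring of the pyrazole hydroxamate series

A few compounds are considered here, and "the series" means these few. Any claim that something is new, unique, unknown or untested is made for them only; others in the source may bear on it.

Measured so far:
compound 1 `O=C(NOCc1ccccc1F)c1cn(-c2ccccc2)nc1-c1ccccc1`, 5940 nM
compound 2 `Cc1ccc(-c2nn(-c3ccccc3)cc2C(=O)NOCc2ccccc2F)cc1`, 260 nM
compound 3 `COc1ccc(-c2nn(-c3ccccc3)cc2C(=O)NOCc2ccccc2)cc1`, 1940 nM

In a functional assay on A549 cells (Homo sapiens) for antiproliferative activity, read by MTT assay, with a stated time of 48 h, in the presence of a further agent that is not named here (on this read-out lower numbers stand for stronger inhibition of growth and higher numbers for weaker inhibition of growth), compound 3 gives the second highest of the three numbers, sitting between compound 1 and compound 2. For the measured compounds named here, the only single-point step measured is a 23-fold lower number from compound 1 to compound 2 (1.36 log units; beyond the scatter), which concerns a different ring. Compound 4 `COc1ccc(-c2nn(-c3ccccc3)cc2C(=O)NOCc2ccccc2F)cc1` differs from compound 3 by fluoro in place of hydrogen on an aromatic carbon. Going by the values given here, no measured step addresses this change; the two compounds that carry the fluorobenzyl group differ from compound 3 elsewhere too, so their values give no isolated reading of it. The expected step of a 1.3-fold lower number from compound 3 to compound 4 (0.11 log units; within the scatter) is therefore none beyond the scatter. Compound 4 is estimated at 1500 nM in this assay, within 500 nM to 4500 nM.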

Compound 4, concentration for 50% growth inhibition: 2160 nM
Compound 4: middle estimate off by 1.4-fold (0.16 log units), on the low side, within the range that was stated.
By their numbers in this assay, from the lowest: compound 2; then compounds 3 and 4 (each within the scatter of the next); then compound 1.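

In this assay, fluoro in place of hydrogen on the benzyl ring leaves the reading within the scatter, with a 1.1-fold higher number from compound 3 to compound 4 (0.05 log units; within the scatter), at least with methoxy on the other aryl ring. With the 2-fluorobenzyl group held constant, that other substituent separates the compounds: methoxy in place of methyl gives an 8.3-fold higher number from compound 2 to compound 4 (0.92 log units; beyond the scatter), and methoxy in place of hydrogen gives a 2.8-fold lower number from compound 1 to compound 4 (0.44 log units; beyond the scatter). No available evidence bears on these steps.

Going by these compounds, whether the fluoro step stays this small alongside methyl or hydrogen remains open. So does the reading for chloro or an amine in place of fluoro.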